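Thiazolyl hydrazones: chloro to methoxy on the aryl ring

The source may report more compounds than this note shows. Statements on the series, on what has been measured and on what is new or still open speak of the compounds shown alone.

Measured compounds in a toxicity assay on THP-1 cells (Homo sapiens) for cytotoxicity, read by MTT assay; on this read-out lower numbers stand for stronger inhibition of growth and higher numbers for weaker inhibition of growth:
- compound 1 `C/C(=N\NC(N)=S)c1sc(C)nc1C` gives > 100 ug/mL, a limit of the assay.
- compound 2 `C/C(=N\Nc1nc(-c2ccc(F)cc2)cs1)c1sc(C)nc1C` gives > 100 ug/mL, also a limit.
- compound 3 `C/C(=N\Nc1nc(-c2ccc(Cl)cc2)cs1)c1sc(C)nc1C` gives > 100 ug/mL, again a limit.

Compound 3 therefore stands at the same limit as the other two compounds; no number is available for it, only the bound (the limit of > 100 ug/mL in this assay, at which 3 of the 3 values shown sit), at which every value of the series sits. Within the data shown here, the one measured step that runs through this part of the series, a step that the two limits leave unreadable from compound 2 to compound 3, is itself unreadable because both of its ends are limits.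

Compound 4 `COc1ccc(-c2csc(N/N=C(\C)c3sc(C)nc3C)n2)cc1` is not yet measured. It differs from compound 3 by methoxy in place of chloro on an aromatic carbon. Among the measured compounds shown here, the only step that bears on this change, a step that the two limits leave unreadable from compound 2 to compound 3, gives no size, so nothing points to any movement in this assay beyond the scatter.

The working expectation is that compound 4 will again return a limit in this assay, with the step from compound 3 to compound 4 estimated as a step that the limit leaves unreadable from compound 3 to compound 4. The estimate for compound 4 is 150 ug/mL, with a range from 60 ug/mL to 400 ug/mL, and the most probable outcome is that only the limit is reported.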

Compound 4, concentration for 50% growth inhibition: > 100 ug/mL
Compound 4 ended at the assay's limit (the forecaster's own chance of this, stated with the estimate: 85%); the middle value does not contradict the limit.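

No step can be read between compound 2, compound 3 and compound 4 in this assay, because both ends of each step are limits: the limit of > 100 ug/mL in this assay, at which 4 of the 4 values shown sit.

The compounds shown leave open how compound 1, compound 2, compound 3 and compound 4 rank in this assay, and whether fluoro, chloro or methoxy on the aromatic carbon makes any difference there.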